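Replacing azetidin-1-yl with (3-fluorophenyl)amino on the shared core

The compounds below may be only part of what the source reports. "The series", "measured", "known", "first", "only" and "open" are said of these compounds alone.

compound 1 `O=C1C(Nc2ccccc2F)=CC(=O)c2c1nc1n2[C@H]2OC[C@@H](O)[C@H]2OC1` gives 2000 nM
compound 2 `O=C1C=C(N2CCC2)C(=O)c2c1nc1n2[C@H]2OC[C@@H](O)[C@H]2OC1` gives > 16000 nM (a limit of the assay, not a number)
compound 3 `O=C1C(Nc2ccc(Br)cc2)=CC(=O)c2c1nc1n2[C@H]2OC[C@@H](O)[C@H]2OC1` gives 2020 nM

In a functional assay on MGC-803 cells (Homo sapiens) for inhibition, read by sulforhodamine B assay (a lower number here means a stronger inhibitor, a higher number a weaker inhibitor), compound 2 stands at the limit of > 16000 nM in this assay, at which 1 of the 3 values shown sits, and that figure is a limit, not a number. Compound 4 `O=C1C=C(Nc2cccc(F)c2)C(=O)c2c1nc1n2[C@H]2OC[C@@H](O)[C@H]2OC1` has not yet been measured. It carries (3-fluorophenyl)amino in place of azetidin-1-yl on a double-bonded ring carbon, counted as (3-fluorophenyl)amino in place of azetidin-1-yl on a double-bonded ring carbon and the rest of the molecule is unchanged.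

The closest evidence comes from the two compounds with a substituted phenyl on an amine nitrogen. Among the measured compounds shown here, the one measured step among them is a 1.0-fold higher number from compound 1 to compound 3 (0.00 log units; within the scatter) and so 4-bromophenyl in place of 2-fluorophenyl made no difference beyond the scatter. Compound 4 also has a substituted phenyl on an amine nitrogen, so it is expected to read close to compound 1 at 2000 nM and compound 3 at 2020 nM in this assay. The expected change is an at least 6.4-fold lower number from compound 2 to compound 4 (0.80 log units; beyond the scatter) towards a lower number, meaning a stronger inhibitor. For compound 4 the estimated value is 2500 nM with an expected range from 1000 nM to 7000 nM in this assay.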

Compound 4, half-maximal inhibitory concentration: 2180 nM
Compound 4: the middle estimate sits 1.1-fold (0.06 log units) above what was measured, within the range that was stated.
By their numbers in this assay, from the lowest: compounds 1, 3 and 4 (each within the scatter of the next). At a limit, above all of these: compound 2.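

In this assay, putting (3-fluorophenyl)amino in place of azetidin-1-yl on a double-bonded ring carbon gives an at least 7.3-fold lower number from compound 2 to compound 4 (0.86 log units; beyond the scatter). Among the compounds shown here, the one earlier step exchanged one substituted phenyl for another and stayed within the scatter, whereas this step replaces a four-membered non-aromatic ring with a six-membered aromatic ring and lies beyond the scatter, so the group at this position can make a clear difference to the read-out. Compound 2 stands at a limit, not a number, so the step gives only a lower bound on the size of the change: the limit of > 16000 nM in this assay, at which 1 of the 4 values shown sits.

The change also adds a hydrogen-bond donor along with the aromatic ring, and these compounds cannot show whether the ring, the donor or both together separate compound 4 from compound 2. A cyclobutylamino group, which has a four-membered carbon ring and keeps the amine hydrogen, and an N-methyl-N-phenylamino group, which has a phenyl ring but no amine hydrogen, would pull these two changes apart.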